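The compounds below may be only part of what the source reports. "The series", "measured", "known", "first", "only" and "open" are said of these compounds alone.

Measured so far in an assay on isolated protein for inhibition of glutathione S-transferase P (Homo sapiens), read by spectrophotometry, with a stated time of 3 min; a higher number here means a weaker inhibitor, a lower number a stronger inhibitor:
compound 1, `CO[C@]1(C)O[C@H]2[C@H](O)C=C(COC(C)=O)C(=O)[C@@H]2O[C@@]1(C)OC`: > 100000 nM
compound 2, `CO[C@H]1C=C(COC(C)=O)C(=O)[C@H](O)[C@H]1O`: > 100000 nM
compound 3, `CO[C@]1(C)O[C@H]2[C@@H](O)C=C(COC(C)=O)C(=O)[C@@H]2O[C@@]1(C)OC`: 82500 nM

Of these, compound 1 has a value that is a limit of the assay, not a number. Compound 2 likewise has a value that is a limit. Among the compounds with values here, compound 3 is therefore the only compound of the three with a number in this assay, and a weak one; it stands alone, with the two other entries being limits, as the limit of > 100000 nM in this assay, at which 2 of the 3 values shown sit, records. Within the data shown here, the single measured step is an at least 1.2-fold lower number from compound 1 to compound 3 (0.08 log units; that floor lies within the scatter); it rests on the fact that compounds 1 and 3 differ only in the configuration as drawn and its floor lies within the scatter, so it carries no information about a change of substituent.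

Compound 4, `CO[C@]1(C)O[C@H]2[C@@H](OC/C=C/c3ccccc3)C=C(COC(C)=O)C(=O)[C@@H]2O[C@@]1(C)OC`, differs from compound 3 in one place: 3-phenylprop-2-en-1-yl in place of hydrogen on an oxygen on a saturated carbon. Among the measured compounds shown here, no measured step concerns a change of this kind, so the data give no direction for it. For the measured compounds named here, the only anchor is compound 3 with its value 82500 nM in this assay.

Compound 4 is expected to give 60000 nM in this assay. The expected range for compound 4 runs from 15000 nM to 150000 nM. This expectation means a step of a 1.4-fold lower number from compound 3 to compound 4 (0.14 log units; within the scatter), which is not beyond the scatter, and the estimate is held wide.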

Compound 4, half-maximal inhibitory concentration: 58000 nM
Compound 4: the middle estimate sits 1.0-fold (0.01 log units) above what was measured, within the range that was stated.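

Replacing hydrogen with 3-phenylprop-2-en-1-yl on an oxygen on a saturated carbon gives, in this assay, a 1.4-fold lower number from compound 3 to compound 4 (0.15 log units; within the scatter). Within the data shown here, this is the first measured step that concerns a substituent rather than a configuration as drawn, and it shows that this position accepts the hydroxy to (3-phenylprop-2-en-1-yl)oxy change with a measurable number retained, so the free hydroxy hydrogen is not needed for the weak inhibition seen with compound 3. The change brings no gain beyond the scatter, and compound 1 and compound 2 remain limits of the assay, not numbers: the limit of > 100000 nM in this assay, at which 2 of the 4 values shown sit.

On these data alone, it remains open whether any group on this oxygen can move the number beyond the scatter, for example a plain methyl, a benzyl, a saturated 3-phenylpropyl chain that would test the double bond, or a longer chain ending in an amine or a carboxylic acid. Also open, as far as these compounds go, is whether 3-phenylprop-2-en-1-yl behaves the same way on the oxygen of compound 1, which differs from compound 3 only in configuration as drawn.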